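The compounds below may be only part of what the source reports. "The series", "measured", "known", "first", "only" and "open" are said of these compounds alone.

Working notes on a series tested in an assay on CHO cells for antagonist activity at transient receptor potential cation channel subfamily V member 1 (Homo sapiens), read by FLIPR; on this read-out higher numbers stand for weaker inhibition and lower numbers for stronger inhibition. Compound 1 `CC(C(=O)NCc1ccc(C(F)(F)F)cc1N1CCC(c2ccc(F)cc2)CC1)c1ccc(NS(C)(=O)=O)c(F)c1` gives 0.9 nM in this assay. Compound 2 `COc1ccc(N2CCN(c3cc(C(F)(F)F)ccc3CNC(=O)C(C)c3ccc(NS(C)(=O)=O)c(F)c3)CC2)cc1` gives 1.6 nM. Compound 3 `CCCOc1cc(C(F)(F)F)ccc1CNC(=O)C(C)c1ccc(NS(C)(=O)=O)c(F)c1` gives 2 nM, the highest of the three numbers; its gap to compound 2 lies within the usual scatter, so no order between those two can be read, while the gap to compound 1 lies beyond the scatter, compound 1 sitting on the lower side. Among the measured compounds shown here, no pair of measured compounds differs in one place only, so no measured step anchors the move to compound 4 `COc1ccc(CSc2cc(C(F)(F)F)ccc2CNC(=O)C(C)c2ccc(NS(C)(=O)=O)c(F)c2)cc1`, which is not yet measured in this assay. The change from compound 3 is (4-methoxybenzyl)sulfanyl in place of propoxy on an aromatic carbon. What the numbers show is that the two larger structures, compound 1 and compound 2, give the lower values, and that the three values together span only a narrow band. Nothing more can be drawn from them for this step. The step from compound 3 to compound 4 is expected to be small, at a 1.3-fold lower number from compound 3 to compound 4 (0.12 log units; within the scatter), either a modest move downward or none beyond the scatter. Compound 4 is estimated at 1.5 nM, with a range of 0.5 nM to 5 nM.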

Compound 4, inhibition constant: 2.3 nM
The estimate for compound 4 lay 1.5-fold (0.19 log units) below the measured number; measured number inside the range.
By their numbers in this assay, from the lowest: compounds 1, 2, 3 and 4 (each within the scatter of the next, the first and the last beyond it).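

Among the compounds shown here, the only single-place step at this position in this assay reads a 1.2-fold higher number from compound 3 to compound 4 (0.06 log units; within the scatter): propoxy leaves and (4-methoxybenzyl)sulfanyl enters. On this aromatic carbon, ortho to a large group and meta to a trifluoromethyl group, a substituent of 10 heavy atoms with a six-membered aromatic ring thus replaces one of 4 heavy atoms with no ring, and the read-out does not move beyond the scatter. No measurement at hand bears on why the number holds across this change.

The step exchanges the oxygen for sulfur and adds the methoxy-bearing aromatic ring in one move, so the share of each cannot be separated; a benzyloxy group or a propylsulfanyl group on the same carbon would pull the two apart. Also open, from the compounds shown here alone, is how the number responds to a group of a different kind at this position, such as an amine or a carboxylic acid, since both substituents compared here carry no net charge and no hydrogen-bond donor.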